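The source may hold more compounds than are shown below. What is called first, only, known or untested is meant among the compounds shown, and "the series" means these compounds.

Measured in a functional assay on C6 cells (Rattus norvegicus) for cytotoxicity, read by MTT assay, with a stated time of 24 h, tested at 50 ug/mL; a lower number here means a stronger effect, a higher number a weaker effect of the compound at the concentration tested:
compound 1 `Cc1nnc(SCC(=O)N/N=c2/scc(-c3ccc(Cl)cc3)n2-c2ccccc2)s1`, 37.9%
compound 2 `Cc1ccc(-c2cs/c(=N/NC(=O)CSc3nncn3C)n2-c2ccccc2)cc1`, 53.8%
compound 3 `Cn1cnnc1SCC(=O)N/N=c1/scc(-c2ccc(C#N)cc2)n1-c1ccccc1`, 58.8%

Compound 2 stands second highest of the three numbers. Its nearest neighbour is compound 3, reached by a number 5 percentage points higher from compound 2 to compound 3 (within the scatter), the change being a cyano in place of methyl on an aromatic carbon. Among the compounds with values here, its furthest neighbour is compound 1, whose 37.9% lies beyond the scatter below that of compound 2; compound 1 differs from compound 2 in two places at once, so no single step is available between them.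

Compound 4 `Cc1ccc(-c2cs/c(=N/NC(=O)CSc3nnc(C)s3)n2-c2ccccc2)cc1` is not yet measured. It differs from compound 2 by 5-methyl-1,3,4-thiadiazol-2-yl in place of 4-methyl-4H-1,2,4-triazol-3-yl on a sulfur. Within the data shown here, no measured step isolates this change. Among the measured compounds shown here, the only step, a number 5 percentage points higher from compound 2 to compound 3 (within the scatter), concerns a substituent on the aromatic carbon and stays within the scatter, so it says nothing about the ring on the sulfur. Compound 1 carries the same 5-methyl-1,3,4-thiadiazol-2-yl ring and gives the lower number of the pair with compound 2, but it also carries a different aryl group, so its value can only hint. A step leaning lower but not clearly beyond the scatter is expected, a number 6.8 percentage points lower from compound 2 to compound 4 (within the scatter). Compound 4 is estimated at 47%, between 34% and 60%.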

Compound 4, a percentage reported as activity, at one concentration (the size of the read-out at that concentration, not a potency): 40.6%
Estimate against measurement, compound 4: 6.4 percentage points above; the measured number falls inside the stated range.
By their numbers in this assay, from the lowest: compounds 1 and 4 (each within the scatter of the next); then compounds 2 and 3 (each within the scatter of the next).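

In this assay, within the data shown here, the ring on the sulfur is the first single change to move the read-out beyond the scatter: a number 13.2 percentage points lower from compound 2 to compound 4 (beyond the scatter), with 5-methyl-1,3,4-thiadiazol-2-yl in place of 4-methyl-4H-1,2,4-triazol-3-yl giving a modestly stronger effect at the concentration tested. The two rings have the same counts of heavy atoms, hetero atoms, donors and acceptors, and differ in composition by one sulfur against one nitrogen, so these counts alone do not separate them. With the 5-methyl-1,3,4-thiadiazol-2-yl ring in place, the aromatic substituent gives no readable change, a number 2.7 percentage points higher from compound 1 to compound 4 (within the scatter), and no measurement available here offers an explanation for the difference between the two rings.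

On these data alone, it remains open whether the same ring change holds with the chloro or cyano substituent on the aromatic carbon, since only the methyl compounds form a matched pair at the sulfur. Also open is how far the result depends on an aromatic ring at this sulfur at all, as a plain ethyl chain or an aminoethyl chain there lies outside the compounds shown.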